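Isopropyl replacing (oxolan-2-yl)methyl: from compound 1 to compound 3

A few compounds are considered here, and "the series" means these few. Any claim that something is new, unique, unknown or untested is made for them only; others in the source may bear on it.

Compound 1 `Cn1cc(-c2ccc(NC(=O)c3cn(CC4CCCO4)cc(-c4ccc(F)cc4)c3=O)cc2)c2c(N)ncnc21` is measured in an assay on isolated protein for inhibition of tyrosine-protein kinase receptor UFO (Homo sapiens), read by ELISA (a higher number here means a weaker inhibitor, a lower number a stronger inhibitor), and gives 1.2 nM. For the measured compounds named here, the only other measured member of the series, compound 2 `Cc1nc(N)c2c(-c3ccc(NC(=O)c4cn(CC5CCOCC5)cc(-c5ccc(F)cc5)c4=O)cc3)cn(C)c2n1`, gives 5.1 nM in this assay. Going by the values given here, of these two numbers, compound 1 has the lower one, and the gap between compound 1 and compound 2 lies beyond the usual scatter of repeated measurements; the two compounds differ in more than one place, so no single structural step is tied to that gap.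

Compound 3 `CC(C)n1cc(C(=O)Nc2ccc(-c3cn(C)c4ncnc(N)c34)cc2)c(=O)c(-c2ccc(F)cc2)c1` is not yet measured in this assay. It differs from compound 1 in one place only: isopropyl in place of (oxolan-2-yl)methyl on an aromatic nitrogen. Among the compounds with values here, no measured pair isolates a change of this kind, so nothing measured here sets the size of the step. The group that leaves and the group that enters both sit on the same aromatic nitrogen, and the remainder of the structure is untouched. A small step, if any, is expected, within or near the usual scatter, and more likely toward a slightly higher number than toward a lower one.

Compound 3 is expected to give 2 nM in this assay, with a range from 0.6 nM to 7 nM. This estimate means an expected step of a 1.7-fold higher number from compound 1 to compound 3 (0.22 log units; within the scatter).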

Compound 3, half-maximal inhibitory concentration: 0.4 nM
Compound 3: middle estimate off by 5.0-fold (0.70 log units), on the high side; measured number below the stated range.
By their numbers in this assay, from the lowest: compound 3; then compound 1; then compound 2.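

In this assay, for the compounds shown here, isopropyl in place of (oxolan-2-yl)methyl on the aromatic nitrogen gives a 3.0-fold lower number from compound 1 to compound 3 (0.48 log units; beyond the scatter), the first single-change step and one that lies beyond the usual scatter. At this position, a low number therefore does not depend on the five-membered non-aromatic ring or the hydrogen-bond acceptor of the leaving group: isopropyl carries neither, and the number still falls. No measurement available here bears on the reason for this step.

This one step changes the ring, the oxygen and the heavy-atom count together, so their separate contributions cannot be told apart; a methyl, a 2-methoxyethyl chain, a longer chain such as n-butyl or a chain ending in an amine on the same aromatic nitrogen would help to separate them. As far as these compounds go, compound 2 differs from compound 1 in more than one place, so it remains open whether isopropyl would give a step of similar size and direction on the core of compound 2.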